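The source may hold more compounds than are shown below. What is called first, only, known or untested is meant among the compounds shown, and "the series" means these compounds.

Measured in a functional assay on NALM-6 cells (Homo sapiens) for cytotoxicity, with a stated time of 72 h; a higher number here means that more compound is needed for the effect, a lower number that less compound is needed:
- compound 1 `C=C[C@@](C)(/C=C/c1ccc(O)c(/C=C/C(=O)OCC)c1)CCC=C(C)C`: 20900 nM
- compound 2 `COc1ccc(/C=C/[C@@](C)(/C=C/c2ccc(O)c(C=O)c2)CCC=C(C)C)cc1`: > 43400 nM, a limit
- compound 3 `COc1ccc(/C=C/[C@@](C)(/C=C/c2ccc(O)c(/C=C/C#N)c2)CCC=C(C)C)cc1`: 16500 nM

Within the data shown here, compound 3, at 16500 nM, lies within the scatter of compound 1, the only other numerical value. Compound 4 `CCOC(=O)/C=C/c1cc(/C=C/[C@](C)(/C=C/c2ccc(OC)cc2)CCC=C(C)C)ccc1O` departs from compound 3 as follows: ethoxycarbonyl in place of cyano on a double-bonded chain carbon bound to a double-bonded chain carbon. In other words, 2-cyanoethenyl gives way to 2-(ethoxycarbonyl)ethenyl. Among the measured compounds shown here, the one measured step bearing on this is an at least 2.6-fold lower number from compound 2 to compound 3 (0.42 log units; beyond the scatter). It brings in 2-cyanoethenyl but does not compare it with 2-(ethoxycarbonyl)ethenyl. Compound 1 carries 2-(ethoxycarbonyl)ethenyl on a different remainder and gives 20900 nM, so no step beyond the scatter is expected in this assay. The expected change is a 1.1-fold higher number from compound 3 to compound 4 (0.04 log units; within the scatter). For compound 4 the estimated value is 18000 nM, with an expected range of 8000 nM to 40000 nM.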

Compound 4, half-maximal effective concentration: > 43400 nM
Compound 4: no number, only a limit (the forecaster's own chance of this, stated with the estimate: 20%); middle value at least 2.4-fold (0.38 log units) from the limit.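

On the core of compound 3, ethoxycarbonyl in place of cyano gives an at least 2.6-fold higher number from compound 3 to compound 4 (0.42 log units; beyond the scatter) in this assay, so this position responds to the change. The 2-(ethoxycarbonyl)ethenyl group also behaves differently across remainders: 2-(4-methoxyphenyl)ethenyl in place of vinyl gives an at least 2.0-fold higher number from compound 1 to compound 4 (0.31 log units; beyond the scatter). The step from compound 2 to compound 4 cannot be read, as both values are limits: the limit of > 43400 nM in this assay, at which 2 of the 4 values shown sit.

On these data alone, how far compound 4 lies past its limit stays open, so both readable steps give only minimum sizes. Also open, as far as these compounds go, is whether a carboxylic acid or a primary amide in place of cyano would stay level with compound 3.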